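The compounds below may be only part of what the source reports. "The series", "measured", "known", "first", "only" and "open" are said of these compounds alone.

In a functional assay on NCI-H460 cells (Homo sapiens) for inhibition, read by MTT assay, with a stated time of 72 h (a lower number here means a stronger inhibitor, a higher number a weaker inhibitor), compound 1 (`COc1cc(OC)cc(N2CCN(C(=O)c3oc(C)nc3-c3ccc(F)cc3)CC2)c1`) gives 68 nM and compound 2 (`Cc1nc(-c2cccc(F)c2)c(C(=O)N2CCN(c3cc(Cl)cc(Cl)c3)CC2)o1`) gives 221 nM, so compound 2 stands highest of the two, by a gap beyond the scatter. Compound 3 (`COc1cc(OC)cc(N2CCN(C(=O)c3oc(C)nc3-c3cccc(F)c3)CC2)c1`) has 3,5-dimethoxyphenyl in place of 3,5-dichlorophenyl on an amine nitrogen in a ring. Among the compounds with values here, no measured pair differs in one place only. Compound 1, at 68 nM, also bears 3,5-dimethoxyphenyl, which points to a lower number. The expected step is a 2.5-fold lower number from compound 2 to compound 3 (0.39 log units; beyond the scatter) in this assay, towards stronger inhibition. For compound 3 the estimated value is 90 nM, with a range of 35 nM to 230 nM.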

Compound 3, half-maximal inhibitory concentration: 67 nM
Estimate against measurement, compound 3: 1.3-fold (0.13 log units) above, within the range that was stated.
By their numbers in this assay, from the lowest: compounds 3 and 1 (each within the scatter of the next); then compound 2.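

In this assay, the swap to 3,5-dimethoxyphenyl from 3,5-dichlorophenyl on the amine nitrogen in a ring, now seen as a one-place comparison, gives a 3.3-fold lower number from compound 2 to compound 3 (0.52 log units; beyond the scatter), a modest gain with 3-fluorophenyl held fixed. With 3,5-dimethoxyphenyl held fixed, 3-fluorophenyl in place of 4-fluorophenyl gives a 1.0-fold lower number from compound 1 to compound 3 (0.01 log units; within the scatter), so these two fluorine placements cannot be told apart here. Nothing available explains either step.

Open, from the compounds shown here alone, is whether an amine or a carboxylic acid in place of the methoxy groups would hold this level. Also open, going by these compounds, is whether the fluorine placement stays equally silent alongside 3,5-dichlorophenyl.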